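The compounds below may be only part of what the source reports. "The series", "measured", "known", "first", "only" and "open" are said of these compounds alone.

Working notes on the series. Compound 1 `COc1cc(-n2cccc2C(=O)O)ccc1Nc1ncc(Cl)c(Nc2ccccc2NS(C)(=O)=O)n1` gives in a functional assay on NCI-H2228 cells (Homo sapiens) for antiproliferative activity, read by MTT assay, with a stated time of 72 h (on this read-out higher numbers stand for weaker inhibition and lower numbers for stronger inhibition), a value of 640 nM. Within the data shown here, compound 2 `CCN1CCN(C(=O)c2cccn2-c2ccc(Nc3ncc(Cl)c(Nc4ccccc4NS(C)(=O)=O)n3)c(OC)c2)CC1` gives in this assay a value of 1130 nM; on the two numbers so far it sits beside compound 1, the only recorded step being a 1.8-fold higher number from compound 1 to compound 2 (0.25 log units; within the scatter), which is the same carbonyl carbon that is varied again below.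

Compound 3 `COc1cc(-n2cccc2C(=O)N2CC(O)C2)ccc1Nc1ncc(Cl)c(Nc2ccccc2NS(C)(=O)=O)n1` is not yet measured. It differs from compound 2 by 3-hydroxyazetidin-1-yl in place of 4-ethylpiperazin-1-yl on a carbonyl carbon. Among the measured compounds shown here, the one measured step that bears on this position is a 1.8-fold higher number from compound 1 to compound 2 (0.25 log units; within the scatter), and it stayed within the scatter even though it exchanged hydroxy for a ring bearing two hetero atoms. A second exchange of the group on the same carbonyl carbon, with one ring for another, is therefore not expected to move this assay beyond the scatter in either direction. For compound 3 the expected value in this assay is 900 nM, with a range of 350 nM to 2300 nM. That estimate amounts to a 1.3-fold lower number from compound 2 to compound 3 (0.10 log units; within the scatter), a step expected to lie within the scatter.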

Compound 3, half-maximal inhibitory concentration: 44 nM
Compound 3: middle estimate off by 20-fold (1.31 log units), on the high side; measured number outside the range, below it.
By their numbers in this assay, from the lowest: compound 3; then compounds 1 and 2 (each within the scatter of the next).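

In this assay the group on the carbonyl carbon is not indifferent: 3-hydroxyazetidin-1-yl in place of 4-ethylpiperazin-1-yl gives a 26-fold lower number from compound 2 to compound 3 (1.41 log units; beyond the scatter), and in place of hydroxy it gives a 15-fold lower number from compound 1 to compound 3 (1.16 log units; beyond the scatter). Both steps lie beyond the scatter, so the flat picture from the earlier exchange at this position holds only for the pair compound 1 and compound 2, and compound 3 stands apart from both. Nothing available on these compounds accounts for the size of these steps.

The compounds shown leave open whether the step goes with the four-membered ring or with its hydroxy group, which unsubstituted azetidin-1-yl would separate. They also leave open whether a hydroxy group on a larger ring, as in 4-hydroxypiperidin-1-yl, or an amine in its place, as in 3-aminoazetidin-1-yl, gives a comparable number.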